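This account rests on a few compounds, and the source may have more. Where it says the series, first, only, none or still open, it means among the compounds named here.

Measured so far in a functional assay for antagonist activity at transient receptor potential cation channel subfamily V member 1 (Homo sapiens), read by FLIPR and calcium flux; on this read-out higher numbers stand for weaker inhibition and lower numbers for stronger inhibition:
- compound 2 `Cc1ccccc1N1CCC(C(=O)Nc2ccc3c(c2)NC(=O)CO3)CC1`: 150 nM
- compound 1 `O=C(Nc1ccc2cc[nH]c2c1)C1CCN(c2cccc(C(F)(F)F)c2)CC1`: > 9000 nM

Compound 2 stands as the only numerical result in this assay. The value for compound 1 is a limit of the assay, not a number; it marks (the limit of > 9000 nM in this assay, at which 1 of the 2 values shown sits). Among the measured compounds shown here, with two compounds and a single number, no step between measured compounds can be drawn, and the two structures differ in more than one place, so their values are set side by side without comparison.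

Compound 3 `O=C1COc2ccc(NC(=O)C3CCN(c4ccccc4Cl)CC3)cc2N1` is the next to be measured in this assay. Against compound 2 the change is chloro in place of methyl on an aromatic carbon. For the measured compounds named here, no measured pair of this kind is available, so the step from compound 2 to compound 3 is expected to be small, without a direction that stands beyond the scatter, and is estimated as no change at the digits printed from compound 2 to compound 3 (within the scatter). For compound 3 the estimate in this assay is 150 nM, within a range from 50 nM to 450 nM.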

Compound 3, half-maximal inhibitory concentration: 220 nM
Estimate against measurement, compound 3: 1.5-fold (0.17 log units) below; the measured number falls inside the stated range.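

In this assay, among the compounds shown here, the exchange of 2-methylphenyl for 2-chlorophenyl gives a 1.5-fold higher number from compound 2 to compound 3 (0.17 log units; within the scatter) and is the only change in one place that can be read so far. At this position, on an aromatic carbon ortho to a large group, chloro and methyl therefore give values within the scatter of each other, so the read-out does not separate these two groups here. Nothing among the available evidence bears on this exchange, and no reason for the result can be given.

As far as these compounds go, what a methoxy group, a nitrile or an amine would give at this same position on the shared core remains open. Also open, from the compounds shown here alone, is whether chloro and methyl would stay this close at another position of the aromatic ring or on another core.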